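Anilinonicotinic hydrazones: paw edema inhibition, ring-nitrogen swap

This account rests on a few compounds, and the source may have more. Where it says the series, first, only, none or still open, it means among the compounds named here.

Measured compounds:
compound 1, `O=C(N/N=C/c1cccc(F)c1)c1cccnc1Nc1cccc(C(F)(F)F)c1`: 51.5%
compound 2, `O=C(N/N=C/c1cccc(Cl)c1)c1cccnc1Nc1cccc(C(F)(F)F)c1`: 76.7%

Both compounds were tested in a functional assay on the whole organism (strain Wistar) for inhibition, with Rattus norvegicus as the target, read by paw edema, with a stated time of 1 h, at a dose of 10 mg/kg by the intraperitoneal route; on this read-out lower numbers stand for less inhibition and higher numbers for more inhibition at the one dose given (going by the name of the read-out). Of the two numbers, compound 2 stands highest; its nearest neighbour is compound 1, which lies lower by the step of a number 25.2 percentage points higher from compound 1 to compound 2 (beyond the scatter). For the measured compounds named here, that single step, chloro in place of fluoro on an aromatic carbon, is the only measured change, and it shows that the halogen on the benzylidene ring is not a neutral position.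

Compound 3, `O=C(N/N=C/c1ccncc1)c1cccnc1Nc1cccc(C(F)(F)F)c1`, has not yet been measured in this assay. It differs from compound 2 by pyridin-4-yl in place of 3-chlorophenyl on a carbon with a double bond to nitrogen. The halogen that separated compound 1 from compound 2 is gone entirely, and a ring nitrogen enters instead. Going by the values given here, no measured pair covers a pyridin-4-yl for 3-chlorophenyl exchange, so the step from compound 1 to compound 2 bears on it only indirectly: loss of the chloro is the part of the change that has some precedent, and that precedent points downward. Compound 3 is therefore expected to come in below compound 2, by an estimated a number 26.7 percentage points lower from compound 2 to compound 3 (beyond the scatter), landing near 50% with a range from 30% to 70%.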

Compound 3, a percentage reported as inhibition, in the whole organism at one dose (the size of the read-out at that dose, not a potency): 70.2%
The estimate for compound 3 lay 20.2 percentage points below the measured number; measured number outside the range, above it.
By their numbers in this assay, from the lowest: compound 1; then compounds 3 and 2 (each within the scatter of the next).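

Working from this assay, the exchange at the carbon with a double bond to nitrogen reads as a number 6.5 percentage points lower from compound 2 to compound 3 (within the scatter), so pyridin-4-yl can stand in for 3-chlorophenyl at this one dose without a change that rises above the scatter, and the chloro is not a requirement at this place. The same exchange made on the fluoro compound gives a number 18.7 percentage points higher from compound 1 to compound 3 (beyond the scatter), which leaves compound 1 as the lowest of the three and shows that the higher numbers occur both with a chloro and with no halogen on the ring, so the low number of compound 1 goes with 3-fluorophenyl rather than with the absence of a chloro. No supporting data bear on why these rings give these numbers.

The compounds shown leave open whether the ring nitrogen itself matters, which a plain phenyl ring or a pyridin-3-yl ring at the same carbon would help to separate. They also leave open whether a ring carrying an amine or a carboxylic acid would hold up, and whether the present order persists at other doses and times.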